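A few compounds are considered here, and "the series" means these few. Any claim that something is new, unique, unknown or untested is made for them only; others in the source may bear on it.

Within the data shown here, compound 2 `CCc1cncc(OC[C@@H]2CCCN2C)c1` holds the lowest of the two numbers available so far in an assay on membranes from brain for displacement of a labelled ligand from Neuronal acetylcholine receptor; alpha4/beta2 (Rattus norvegicus); on this read-out higher numbers stand for weaker inhibition and lower numbers for stronger inhibition; in this assay compound 2 gives 0.32 nM, while its nearest neighbour compound 1 `CN1CCC[C@H]1COc1cccnc1I` gives 606 nM, a gap that lies beyond the usual scatter. Among the measured compounds shown here, no step between two measured compounds that differ in a single place is at hand, so the next change is judged from the structures alone. Compound 3 `CN1CCC[C@H]1COc1cncc(F)c1` differs from compound 2 by fluoro in place of ethyl on an aromatic carbon. With fluoro in place of ethyl on an aromatic carbon, compound 3 is expected to stay close to compound 2, with a step of a 1.9-fold higher number from compound 2 to compound 3 (0.27 log units; within the scatter) that may not exceed the scatter. In this assay compound 3 is estimated at 0.6 nM, within 0.15 nM to 3 nM.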

Compound 3, inhibition constant: 0.69 nM
Compound 3: middle estimate off by 1.2-fold (0.06 log units), on the low side; the measured number falls inside the stated range.
By their numbers in this assay, from the lowest: compound 2; then compound 3; then compound 1.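

In this assay, among these compounds, the exchange of ethyl for fluoro on this aromatic carbon, two atoms from the ring nitrogen, gives a 2.2-fold higher number from compound 2 to compound 3 (0.33 log units; beyond the scatter), the first step that can be read between compounds differing in one place. The position therefore accepts a single fluorine in place of the two-carbon group at only a modest cost, with compound 3 still at 0.69 nM. Nothing measured here explains this step. As far as these compounds go, whether an amine, a carboxylic acid or a longer chain at this position would keep the number this low remains open. So does whether the same exchange would give a similar step elsewhere on the ring.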